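The source may hold more compounds than are shown below. What is called first, only, known or untested is meant among the compounds shown, and "the series" means these compounds.

Of the compounds shown here, two have been measured in an assay for activation of prostaglandin D2 receptor 2 (Homo sapiens), read by flow cytometry, with a stated time of 15 min; a higher number here means a larger maximal response, a lower number a smaller maximal response. Compound 1, `CN(c1ccc(-c2cc(C(F)(F)F)ccc2OCC(=O)O)c(Cl)c1)S(C)(=O)=O`, gives 0.92 in this assay, a response close to that of the reference agonist. Compound 2, `CCC(Oc1ccc(C(F)(F)F)cc1-c1ccc(S(=O)(=O)CC)cc1C)C(=O)O`, is built on a different core. In this assay compound 2 reaches only <= 0.1, which is a limit of the assay rather than a number. Compound 2 thus stands at the limit of <= 0.1 in this assay, at which 1 of the 2 values shown sits, and the largest response it produced could not be told apart from no response at all.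

Compound 3, `CCS(=O)(=O)c1ccc(-c2cc(C(F)(F)F)ccc2OC(C)(C)C(=O)O)c(C)c1`, keeps everything of compound 2 except one group: 1-carboxy-1-methylethyl in place of 1-carboxypropyl on an oxygen on an aromatic ring. Going by the values given here, no pair of measured compounds differing in a single place is available, and the size of this step has to be judged from the structures alone. A change that swaps one short branch on the oxygen for another of the same size is expected to move the maximal response little, if at all. The step from compound 2 to compound 3 is expected to be a number at least 0.050 higher from compound 2 to compound 3 (that floor lies within the scatter), within the scatter or only just beyond it. Compound 3 is therefore estimated at 0.15, with a range from 0 to 0.45, and a fair chance that this assay again reports only a limit for it.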

Compound 3, intrinsic activity: the largest response reached, as a fraction of the reference agonist's: <= 0.1
Compound 3 was reported as a limit (the forecaster's own chance of this, stated with the estimate: 50%); middle value at least 0.050 from the limit.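

Compound 2 and compound 3 are each reported only as a limit of the assay, so no step between them can be read: the limit of <= 0.1 in this assay, at which 2 of the 3 values shown sit.

The compounds shown leave open whether exchanging 1-carboxypropyl for 1-carboxy-1-methylethyl on the oxygen changes the maximal response at all.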